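This account rests on a few compounds, and the source may have more. Where it says the series, first, only, none or still open, it means among the compounds named here.

Compound 1 `COc1ccc(/C=C/C(=O)/C=C/c2cc3ccccc3nc2Oc2ccccc2)c(OC)c1`: > 10000 nM (a limit)
Compound 2 `COc1ccc(/C=C/C(=O)/C=C/c2cc3ccccc3nc2Oc2ccccc2)cc1OC`: > 10000 nM (a limit)

In a functional assay on NCI-H460 cells (Homo sapiens) for cytotoxicity, read by MTT assay, with a stated time of 48 h (a lower number here means a stronger inhibitor, a higher number a weaker inhibitor), compound 2 gives no number, only the limit > 10000 nM. Both measured compounds stand at the limit of > 10000 nM in this assay, at which 2 of the 2 values shown sit. Among the measured compounds shown here, the one measured step, a step that the two limits leave unreadable from compound 1 to compound 2, therefore gives no size to build on.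

Compound 3 `COc1cc(OC)c(OC)cc1/C=C/C(=O)/C=C/c1cc2ccccc2nc1Oc1ccccc1` differs from compound 2 by methoxy in place of hydrogen on an aromatic carbon. With no readable step, no clear change in either direction is expected.

The expected step is a step that the limit leaves unreadable from compound 2 to compound 3. For compound 3 the estimated value is 15000 nM, with an expected range from 4000 nM to 50000 nM.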

Compound 3, half-maximal inhibitory concentration: 8030 nM
For compound 3 the middle estimate is 1.9-fold (0.27 log units) above the measured one; the range from low to high includes it.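

In this assay, among the compounds shown here, compound 3, which carries the added methoxy on an aromatic carbon ortho to a large group, is the first compound here to give a real number, 8030 nM. The change can be read only as a floor, an at least 1.2-fold lower number from compound 2 to compound 3 (0.09 log units; that floor lies within the scatter), and likewise an at least 1.2-fold lower number from compound 1 to compound 3 (0.09 log units; that floor lies within the scatter). Its true size stays unknown, as the other values are limits: the limit of > 10000 nM in this assay, at which 2 of the 3 values shown sit.

On these data alone, whether an amine or a hydroxy group at this same place would give a lower number remains open. So does the effect of a longer chain, such as ethoxy, there.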